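Fluoro for Methyl: Cytotoxicity on a Shared Core

The source may hold more compounds than are shown below. What is called first, only, known or untested is meant among the compounds shown, and "the series" means these compounds.

Measured compounds:
compound 1, `NS(=O)(=O)c1ccc(N2N=C(c3ccc(Oc4ccccc4)cc3)CC2c2ccccc2)cc1`: 42000 nM
compound 2, `Cc1cccc(C2CC(c3ccc(Oc4ccccc4)cc3)=NN2c2ccc(S(N)(=O)=O)cc2)c1`: 35000 nM

Of the compounds shown here, two share one core and have been measured in an ADME assay on MT4 cells (Homo sapiens) for cytotoxicity, read by MTT assay, with a stated time of 96 h; on this read-out lower numbers stand for higher toxicity in this test and higher numbers for lower toxicity in this test. Compound 1 gives 42000 nM and compound 2 gives 35000 nM. Among the compounds with values here, the one step between them, a 1.2-fold lower number from compound 1 to compound 2 (0.08 log units; within the scatter), places the two within the scatter of each other, so neither can be called more or less toxic than the other. Within the data shown here, compound 2 stands at the lowest of the two numbers, with compound 1 as its only neighbour, and the gap does not rise above the scatter.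

Compound 3, `NS(=O)(=O)c1ccc(N2N=C(c3ccc(Oc4ccccc4)cc3)CC2c2cccc(F)c2)cc1`, is not yet measured. It differs from compound 2 in one place: fluoro in place of methyl on an aromatic carbon, which read one bond further out is 3-methylphenyl to 3-fluorophenyl. Among the measured compounds shown here, only the step from compound 1 to compound 2 touches this position, and it stayed within the scatter. On that basis no step beyond the scatter is expected in this assay, in either direction, for compound 3, so that a 1.1-fold higher number from compound 2 to compound 3 (0.04 log units; within the scatter) is the estimated step. Compound 3 is therefore expected to give 38000 nM, with a range from 15000 nM to 95000 nM, pending the measurement.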

Compound 3, half-maximal cytotoxic concentration: 25000 nM
Estimate against measurement, compound 3: 1.5-fold (0.18 log units) above, within the range that was stated.
By their numbers in this assay, from the lowest: compounds 3, 2 and 1 (each within the scatter of the next).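

With fluoro at this position, the change from 3-methylphenyl to 3-fluorophenyl in this assay gives a 1.4-fold lower number from compound 2 to compound 3 (0.15 log units; within the scatter), and fluoro in place of hydrogen on the same aromatic carbon gives a 1.7-fold lower number from compound 1 to compound 3 (0.23 log units; within the scatter). The earlier compounds had shown only methyl in place of hydrogen here, whereas this aromatic carbon has now carried hydrogen, methyl and fluoro, and none of the steps among the three compounds rises above the scatter, so this read-out does not separate them and none can be called more or less toxic than another. Nothing available bears on why the numbers fall where they do.

The compounds shown leave open whether an amine, a carboxylic acid or a longer chain such as propyl on this aromatic carbon would give a step beyond the scatter in this assay. They also leave open whether fluoro or methyl on another carbon of this ring would read the same way, since all three compounds differ only at this one position.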